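Cyano in Place of Nitro on a Benzamide Diacid

The source may hold more compounds than are shown below. What is called first, only, known or untested is meant among the compounds shown, and "the series" means these compounds.

Three benzamides have been measured in a functional assay on the whole organism with Rattus norvegicus as the target, at a dose of 25 mg/kg by the intravenous route; a higher number here means that more compound is needed for the effect, a lower number that less compound is needed. Compound 1 `O=C(Nc1ccccc1)c1ccc(-c2nn[nH]n2)cc1` gives 8.4 mg/kg. Compound 2 `O=C(O)c1ccc(NC(=O)c2ccc(C(=O)O)cc2)cc1` gives 25.4 mg/kg, and compound 3 `O=C(Nc1ccc(C(=O)O)c(C(=O)O)c1)c1ccc([N+](=O)[O-])cc1` gives 13.2 mg/kg. Among these three numbers compound 3 stands second highest, yet its gaps to compound 1 and to compound 2 both lie within the scatter, so no order among the three can be claimed. Compound 4 `N#Cc1ccc(C(=O)Nc2ccc(C(=O)O)c(C(=O)O)c2)cc1` has not yet been measured in this assay. It differs from compound 3 in a single place: cyano in place of nitro on an aromatic carbon. Within the data shown here, no measured pair shows this change, and no two of the measured compounds differ in one place alone. A step of no more than the scatter is expected, a 1.0-fold lower number from compound 3 to compound 4 (0.01 log units; within the scatter), with no direction favoured. Compound 4 is accordingly estimated at 13 mg/kg, with a range from 6 mg/kg to 28 mg/kg.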

Compound 4, dose for 50% inhibition: 10.1 mg/kg
For compound 4 the middle estimate is 1.3-fold (0.11 log units) above the measured one; the measured number falls inside the stated range.
By their numbers in this assay, from the lowest: compounds 1, 4, 3 and 2 (each within the scatter of the next, the first and the last beyond it).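

Cyano in place of nitro on this aromatic carbon, para to a large group, gives a 1.3-fold lower number from compound 3 to compound 4 (0.12 log units; within the scatter) in this assay and so provides the first pair in the set that differs in one place. At this position, a nitro group of 3 heavy atoms gives way to a cyano group of 2 with no shift that can be told from the scatter. Nothing measured here explains this result. As far as these compounds go, whether an amine or a methoxy group at this position would also stay within the scatter remains open. From the compounds shown here alone, whether the same change would read alike on another core also remains open.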